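This account rests on a few compounds, and the source may have more. Where it says the series, first, only, none or still open, it means among the compounds named here.

Measured compounds:
- Compound 1, `O=C(Oc1cccc(F)c1OC(=O)c1cc(O)c(O)c(O)c1)c1cc(O)c(O)c(O)c1`: in a functional assay on NCI-H1299 cells (Homo sapiens) for inhibition, read by scintillation counting, with a stated time of 30 min, tested at 30 uM (on this read-out higher numbers stand for more inhibition at the one concentration tested (going by the name of the read-out) and lower numbers for less inhibition), compound 1 gives 81.1%.
- Compound 2, `COc1cccc(OC(=O)c2cc(O)cc(O)c2)c1OC(=O)c1cc(O)cc(O)c1`: in this assay compound 2 gives 69.4%.
- Compound 3, `COc1cccc(OC(=O)c2ccc(O)cc2)c1OC(=O)c1ccc(O)cc1`: in this assay compound 3 gives 86.5%.

Compound 3 holds the highest of the three numbers. Its nearest neighbour is compound 1, whose number is lower by an amount within the usual scatter, so the two cannot be told apart; compound 2 sits furthest, lower by an amount beyond the scatter.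

The next compound, compound 4, `O=C(Oc1cccc(F)c1OC(=O)c1ccc(O)cc1)c1ccc(O)cc1`, has not yet been measured in this assay. It differs from compound 3 in one place: fluoro in place of methoxy on an aromatic carbon. Going by the values given here, no measured pair of compounds shows this exact change, so its effect can only be guessed. Compound 1, which also carries a fluoro on its core, gives a number within the scatter of compound 3, which offers no hint of a large shift in either direction. The account therefore expects a step from compound 3 to compound 4 of a number 4.5 percentage points lower from compound 3 to compound 4 (within the scatter), that is, no change beyond the scatter. Compound 4 is estimated at 82%, with a range from 65% to 95%.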

Compound 4, a percentage reported as inhibition, at one concentration (the size of the read-out at that concentration, not a potency): 92.6%
The estimate for compound 4 lay 10.6 percentage points below the measured number; the range from low to high includes it.
By their numbers in this assay, from the lowest: compound 2; then compounds 1, 3 and 4 (each within the scatter of the next, the first and the last beyond it).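

Going by these compounds alone, on the aromatic carbon that is ortho to a large group and meta to a large group, the exchange of methoxy for fluoro gives, in this assay, a number 6.1 percentage points higher from compound 3 to compound 4 (within the scatter), the first direct reading of this change. The position therefore keeps a high inhibition number without the methoxy, and this one pair shows no need for that group at the one concentration tested. No measurement shown here gives a reason for this result.

As far as these compounds go, whether an amine, a chloro or an ethoxy at this position would move the number beyond the scatter remains open. Also open, from the compounds shown here alone, is whether the exchange would give a similar step with the other hydroxylated benzoyl groups, and how the compounds would compare as potencies rather than at a single concentration.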